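This account rests on a few compounds, and the source may have more. Where it says the series, first, only, none or still open, it means among the compounds named here.

Measured so far:
Compound 1, `COc1ccc(-c2cncnc2-c2cc(OC)c(OC)c(OC)c2)cc1`: 2850 nM
Compound 2, `COc1ccc(-c2cncnc2-c2cc(OC)c(OC)c(OC)c2)cc1F`: 3340 nM
Compound 3, `COc1ccc(-c2cncnc2-c2cc(OC)c(OC)c(OC)c2)cc1Cl`: 1330 nM

These three compounds were tested in a functional assay on SiHa cells (Homo sapiens) for antiproliferative activity, read by CCK-8 assay, with a stated time of 72 h; a higher number here means a weaker inhibitor, a lower number a stronger inhibitor. Compound 2 gives the highest of the three numbers; compound 1 sits nearest, and the two differ by a 1.2-fold higher number from compound 1 to compound 2 (0.07 log units; within the scatter), while compound 3 lies furthest, the step being a 2.5-fold lower number from compound 2 to compound 3 (0.40 log units; beyond the scatter). The third step, from compound 1 to compound 3, is a 2.1-fold lower number from compound 1 to compound 3 (0.33 log units; beyond the scatter).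

Compound 4, `COc1cc(-c2ncncc2-c2ccc(B(O)O)cc2)cc(OC)c1OC`, has not been measured. It differs from compound 2 in one place: a group of 9 heavy atoms (6 carbon, 1 boron, 2 oxygen; one six-membered aromatic ring of carbon only) in place of a group of 9 heavy atoms (7 carbon, 1 oxygen, 1 fluorine; one six-membered aromatic ring of carbon only), on an aromatic carbon. Within the data shown here, every measured step so far swapped only a single small atom on the same ring, and those swaps moved this assay by at most a modest amount. None of them touches a methoxy or introduces a boron-bearing group, so they offer no direct guide. Among the measured compounds shown here, with no comparable step to lean on, the outlook for compound 4 is uncertain, and a wider spread than any measured step is allowed for. Compound 4 is expected to give about 8000 nM in this assay, between 2000 nM and 30000 nM, which would mean an estimated step of a 2.4-fold higher number from compound 2 to compound 4 (0.38 log units; beyond the scatter).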

Compound 4, half-maximal inhibitory concentration: 17500 nM
Beside the measured number, compound 4's estimate is 2.2-fold (0.34 log units) below it, and the stated range covers the measured number.
By their numbers in this assay, from the lowest: compound 3; then compounds 1 and 2 (each within the scatter of the next); then compound 4.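

Until now only a single small atom had changed on this ring, but compound 4 replaces the methoxy itself with a boron-bearing group, and in this assay that gives a 6.1-fold higher number from compound 1 to compound 4 (0.79 log units; beyond the scatter), so this place responds more strongly to a change of the whole group. Among these compounds, the same exchange starting from the halogen-bearing compounds gives a 5.2-fold higher number from compound 2 to compound 4 (0.72 log units; beyond the scatter) and a 13-fold higher number from compound 3 to compound 4 (1.12 log units; beyond the scatter), the last being the only step in this set printed as large. Nothing measured here bears on why the new group gives a higher number.

The compounds shown leave open whether the higher number comes from losing the methoxy or from the boron-bearing group that enters. A carboxylic acid, an amine or a longer alkoxy chain at the same place would help tell these two apart.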